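Removing the chloro group from an aryl urea on a shared core

The source may hold more compounds than are shown below. What is called first, only, known or untested is meant among the compounds shown, and "the series" means these compounds.

Measured compounds:
compound 1, `Cc1cccc(NC(=O)Nc2nnc(Sc3ncnc4scc(-c5ccncc5)c34)s2)c1`: 20700 nM
compound 2, `O=C(Nc1cccc(C(F)(F)F)c1)Nc1nnc(Sc2ncnc3scc(-c4ccncc4)c23)s1`: 15300 nM
compound 3, `Cc1ccc(NC(=O)Nc2nnc(Sc3ncnc4scc(-c5ccncc5)c34)s2)cc1Cl`: 16000 nM

All three share the same core and differ only in the aryl group on the urea nitrogen. In a functional assay on HepG2 cells (Homo sapiens) for antiproliferative activity, read by MTT assay, with a stated time of 48 h (on this read-out lower numbers stand for stronger inhibition and higher numbers for weaker inhibition), compound 1 gives 20700 nM, compound 2 gives 15300 nM and compound 3 gives 16000 nM. Compound 3 stands among numbers that all lie close together: its nearest neighbour is compound 2, with a 1.0-fold higher number from compound 2 to compound 3 (0.02 log units; within the scatter), and its furthest is compound 1, with a 1.3-fold lower number from compound 1 to compound 3 (0.11 log units; within the scatter); the remaining comparison, a 1.4-fold lower number from compound 1 to compound 2 (0.13 log units; within the scatter), is likewise within the scatter.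

Compound 4, `Cc1ccc(NC(=O)Nc2nnc(Sc3ncnc4scc(-c5ccncc5)c34)s2)cc1`, differs from compound 3 by hydrogen in place of chloro on an aromatic carbon. Within the data shown here, the step that bears on it most is the one where the chloro group was added, a 1.3-fold lower number from compound 1 to compound 3 (0.11 log units; within the scatter), which stayed within the scatter, as did the other aryl changes. For compound 4 the step of a 1.1-fold higher number from compound 3 to compound 4 (0.05 log units; within the scatter) is therefore expected to be none beyond the scatter. Compound 4 is estimated at 18000 nM, with a range from 9000 nM to 38000 nM.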

Compound 4, half-maximal inhibitory concentration: 52000 nM
Beside the measured number, compound 4's estimate is 2.9-fold (0.46 log units) below it; measured number outside the range, above it.
By their numbers in this assay, from the lowest: compounds 2, 3 and 1 (each within the scatter of the next); then compound 4.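

In this assay the chloro group at this place does matter: with hydrogen in its place there is a 3.3-fold higher number from compound 3 to compound 4 (0.51 log units; beyond the scatter), while the earlier aryl changes all stayed within the scatter. Compound 4 also lies apart from the other two, with a 3.4-fold higher number from compound 2 to compound 4 (0.53 log units; beyond the scatter) and a 2.5-fold higher number from compound 1 to compound 4 (0.40 log units; beyond the scatter), which makes 4-methylphenyl the weakest of these four aryl groups, yet compound 1 goes against any simple rule that chloro is needed, since it carries none and stays within the scatter of compound 3. No measurement here explains why the loss occurs.

Whether chloro itself is required stays open, as the compounds shown do not tell how a fluoro, bromo or methoxy group at this place would read. How an amine or a carboxylic acid there would behave is equally unknown.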